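From benzamido to 4-carboxyphenyl on the shared core

The compounds below may be only part of what the source reports. "The series", "measured", "known", "first", "only" and "open" are said of these compounds alone.

In a functional assay on MCF7 cells (Homo sapiens) for cytotoxicity, read by sulforhodamine B assay, with a stated time of 24 h (on this read-out lower numbers stand for stronger inhibition and higher numbers for weaker inhibition), compound 1 `CC(=O)N/N=C1\C(=O)Nc2ccc(S(=O)(=O)N3CCOCC3)cc21` gives 56000 nM, while compound 2 `O=C1Nc2ccc(S(=O)(=O)N3CCOCC3)cc2/C1=N/NC(=O)c1ccccc1` gives 414000 nM, the higher of the two numbers and therefore the weaker result. For the measured compounds named here, the only measured step is a 7.4-fold higher number from compound 1 to compound 2 (0.87 log units; beyond the scatter), with phenyl in place of methyl on a carbonyl carbon. This modest step lies beyond the scatter.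

Compound 3 `O=C1Nc2ccc(S(=O)(=O)N3CCOCC3)cc2/C1=N/c1ccc(C(=O)O)cc1` shares its core with compound 2 and differs by one group: 4-carboxyphenyl in place of benzamido on a double-bonded nitrogen. In words, this is 4-carboxyphenyl in place of benzamido on a double-bonded nitrogen. Going by the values given here, no measured pair tests this exchange directly, so the evidence for its effect is thin. Among the compounds with values here, the single guide to size is a 7.4-fold higher number from compound 1 to compound 2 (0.87 log units; beyond the scatter), and a change of modest size is therefore expected here as well. Compound 2 stands at the high end of a very short series, so the expected direction is toward a lower number, though with little certainty. The estimated change is a 2.3-fold lower number from compound 2 to compound 3 (0.36 log units; beyond the scatter). For compound 3, the expected value in this assay is 180000 nM, within an estimated range from 45000 nM to 600000 nM.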

Compound 3, half-maximal inhibitory concentration: 26700 nM
Beside the measured number, compound 3's estimate is 6.7-fold (0.83 log units) above it; the whole stated range lies above it.
By their numbers in this assay, from the lowest: compound 3; then compound 1; then compound 2.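

Compound 1 and compound 2 differed only in the group on the carbonyl carbon, so both kept an amido group on the double-bonded nitrogen, whereas compound 3 replaces that whole group with 4-carboxyphenyl. In this assay this exchange gives a 16-fold lower number from compound 2 to compound 3 (1.19 log units; beyond the scatter), a large step that shows this position can move the number further than the earlier change did. The comparison with the other amido compound is smaller, a 2.1-fold lower number from compound 1 to compound 3 (0.32 log units; beyond the scatter), yet it places compound 3 lowest of the three and shows that an amido group on this nitrogen is not needed for the lowest number seen so far, and no measurement given here explains why the number falls with this exchange.

The compounds shown leave open whether the carboxylic acid or the phenyl ring of the 4-carboxyphenyl group accounts for the step, a question that a plain phenyl, a methyl ester or a primary amide at this place could help to separate. They also leave open whether an amine on the same ring, or a longer chain carrying the carboxylic acid, would lower the number further.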